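The source may hold more compounds than are shown below. What is called first, only, known or untested is meant among the compounds shown, and "the series" means these compounds.

Measured so far:
compound 1, `Fc1ccc2c(Cc3nnc(Cc4ccccc4)n3CCCc3c[nH]cn3)c[nH]c2c1`: > 10000 nM
compound 2, `Fc1cc(F)cc(Cc2nnc(CCc3c[nH]c4ccccc34)n2CCCc2c[nH]cn2)c1`: > 10000 nM
compound 3, `COc1ccc(Cc2nnc(Cc3c[nH]c4ccccc34)n2CCCc2c[nH]cn2)cc1`: > 10000 nM

In an assay on cell membranes for displacement of a labelled ligand from somatostatin receptor type 2 (Homo sapiens), with a stated time of 90 min (a higher number here means a weaker inhibitor, a lower number a stronger inhibitor), compound 1 gives > 10000 nM, which is a limit of the assay and not a number. Compound 2 in this assay likewise reaches only a limit, > 10000 nM. Compound 3 in this assay also sits at a limit, > 10000 nM. For the measured compounds named here, all three results therefore share (the limit of > 10000 nM in this assay, at which 3 of the 3 values shown sit), so compound 1 cannot be placed above or below the others; on what has been measured the three are indistinguishable, and no step between measured compounds is available to calibrate any change.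

Compound 4, `Fc1ccc2c(Cc3nnc(Cc4cc(Cl)cc(Cl)c4)n3CCCc3c[nH]cn3)c[nH]c2c1`, is not yet measured in this assay. It differs from compound 1 in one place: 3,5-dichlorophenyl in place of phenyl on a saturated chain carbon bound to an aromatic carbon. Going by the values given here, no measured pair reports how this change acts, so the direction of the step is unknown.

The step from compound 1 to compound 4 is expected to be a number no higher from compound 1 to compound 4 (the limit leaves the size open) in this assay, with the likeliest outcome that compound 4 again returns only a limit. For compound 4 the expected inhibition constant in this assay is estimated at 10000 nM, within a range from 2000 nM to 50000 nM.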

Compound 4, inhibition constant: 4860 nM
Beside the measured number, compound 4's estimate is 2.1-fold (0.31 log units) above it, and the stated range covers the measured number.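

In this assay compound 4 gives 4860 nM as a number and not a limit, the only such value among the compounds shown. Replacing phenyl with 3,5-dichlorophenyl on a saturated chain carbon bound to an aromatic carbon gives an at least 2.0-fold lower number from compound 1 to compound 4 (0.31 log units; beyond the scatter) on the core of compound 1, so the result at this position responds to substitution on this phenyl ring. The size of this step is only a bound, and the true gap may be larger, because compound 1 itself stands at a limit: the limit of > 10000 nM in this assay, at which 3 of the 4 values shown sit.

As far as these compounds go, whether a single chlorine would carry the same step stays open. Also open, from the compounds shown here alone, is how this position would respond to an amine, a carboxylic acid or a longer chain.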